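Shortening the Linker of an Iodoacetamide Nucleotide

A few compounds are considered here, and "the series" means these few. Any claim that something is new, unique, unknown or untested is made for them only; others in the source may bear on it.

Three compounds share one core and carry an iodoacetamide at the end of a chain that joins a nitrogen on the core. Compound 1 `O=C(CI)NCCCCCCCCNc1ncnc2c1ncn2[C@@H]1O[C@H](COP(=O)(O)OP(=O)(O)OP(=O)(O)O)[C@@H](O)[C@H]1O` gives the highest number of the three: in an assay on isolated protein for inhibition of hexokinase-2 (Rattus norvegicus), with a stated time of 6 h, tested at 10 mM (a lower number here means less inhibition, a higher number more inhibition at the concentration tested (going by the name of the read-out)), compound 1 gives 41%. Compound 3 `O=C(CI)NCCNc1ncnc2c1ncn2[C@@H]1O[C@H](COP(=O)(O)OP(=O)(O)OP(=O)(O)O)[C@@H](O)[C@H]1O` differs from it in one place, and in this assay compound 3 gives 0%, the loss being a number 41 percentage points lower from compound 1 to compound 3 (beyond the scatter). Compound 2 `O=C(CI)NCCCCCCC(=O)NCCCCCCNc1ncnc2c1ncn2[C@@H]1O[C@H](COP(=O)(O)OP(=O)(O)OP(=O)(O)O)[C@@H](O)[C@H]1O` has an amide within its chain, and in this assay compound 2 gives 0%, level with compound 3 at the digits shown and together with it the lowest of the three.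

Compound 4 `O=C(CI)NCCCC(=O)NCCCCCCNc1ncnc2c1ncn2[C@@H]1O[C@H](COP(=O)(O)OP(=O)(O)OP(=O)(O)O)[C@@H](O)[C@H]1O` differs from compound 2 by one change: ((iodomethyl)carbonyl)amino in place of 3-(((iodomethyl)carbonyl)amino)propyl on a saturated chain carbon, three bonds along the chain from a carbonyl carbon. Within the data shown here, the only measured step of a comparable kind, a number 41 percentage points lower from compound 1 to compound 3 (beyond the scatter), was a shortening that removed inhibition entirely. Compound 2 already sits at the floor of the scale, with nothing left to lose. For compound 4 the expected step is therefore a number 2 percentage points higher from compound 2 to compound 4 (within the scatter), nothing beyond the scatter. Compound 4 is estimated at 2%, in the range 0% to 12%.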

Compound 4, a percentage reported as inhibition, at one concentration (the size of the read-out at that concentration, not a potency): 0%
Compound 4: middle estimate off by 2 percentage points, on the high side; the range from low to high includes it.
By their numbers in this assay, from the lowest: compounds 2, 3 and 4 (each within the scatter of the next); then compound 1.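

Replacing 3-(((iodomethyl)carbonyl)amino)propyl with ((iodomethyl)carbonyl)amino on this chain gives no change at the digits printed from compound 2 to compound 4 (within the scatter), so two lengths of amide-containing chain now read alike in this assay, both at the bottom of the scale, where a further loss could not show. The comparison with the unbroken carbon chain gives a number 41 percentage points lower from compound 1 to compound 4 (beyond the scatter), which leaves compound 1 as the only one of the four with a reading beyond the scatter of the others. No independent measurement here offers a reason for this pattern.

The compounds shown leave open whether the amide in the chain or the chain's length decides the outcome. An unbroken carbon chain as long as that of compound 2, or an ether oxygen in place of the amide, would help separate the two.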